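Swapping the aryl ether: difluorophenyl to methylphenyl

The source may hold more compounds than are shown below. What is called first, only, known or untested is meant among the compounds shown, and "the series" means these compounds.

Compound 1 `Cc1nn(C)c(Oc2ccc(F)cc2F)c1/C=N\CCCCCCOc1cc2oc(=O)cc(C)c2cc1Cl`: > 25000 nM
Compound 2 `Cc1nn(C)c(Oc2cccc(Cl)c2)c1/C=N\CCCCCCOc1cc2oc(=O)cc(C)c2cc1Cl`: 8460 nM
Compound 3 `Cc1nn(C)c(Oc2ccccc2Br)c1/C=N\CCCCCCOc1cc2oc(=O)cc(C)c2cc1Cl`: 21800 nM

Of the compounds shown here, three have been tested in a functional assay on U-87MG ATCC cells for antiproliferative activity against U-87 MG (Homo sapiens), read by MTT assay, with a stated time of 72 h; on this read-out higher numbers stand for weaker inhibition and lower numbers for stronger inhibition. Compound 1 reaches only the limit of the assay, (the limit of > 25000 nM in this assay, at which 1 of the 3 values shown sits), so for compound 1 there is a bound rather than a number. In this assay compound 2 gives 8460 nM, and compound 3 gives 21800 nM.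

Compound 4 `Cc1ccccc1Oc1c(/C=N\CCCCCCOc2cc3oc(=O)cc(C)c3cc2Cl)c(C)nn1C` has not yet been measured. It differs from compound 1 in one place: 2-methylphenyl in place of 2,4-difluorophenyl on an oxygen on an aromatic ring.

Two measured steps start from compound 1 and exchange the same group. One of them, an at least 2.9-fold lower number from compound 1 to compound 2 (0.47 log units; beyond the scatter), lies beyond the scatter. The other, an at least 1.1-fold lower number from compound 1 to compound 3 (0.05 log units; that floor lies within the scatter), has a floor within the scatter. Between the two replacement groups, a 2.6-fold higher number from compound 2 to compound 3 (0.41 log units; beyond the scatter). Compound 1 stands at a limit, so both steps from it are floors rather than measured sizes. Within the data shown here, the 2-methylphenyl group in compound 4 is neither of the groups tried so far, and no measured step bears on it directly.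

Compound 4 is therefore expected to give about 18000 nM in this assay, with a range from 7000 nM to 40000 nM. The expected step of an at least 1.3-fold lower number from compound 1 to compound 4 (0.14 log units; that floor lies within the scatter) is at most a small gain, and may be none beyond the scatter.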

Compound 4, half-maximal inhibitory concentration: 9610 nM
Compound 4: middle estimate off by 1.9-fold (0.27 log units), on the high side; the measured number falls inside the stated range.
By their numbers in this assay, from the lowest: compounds 2 and 4 (each within the scatter of the next); then compound 3. At a limit, above all of these: compound 1.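

In this assay the change from 2,4-difluorophenoxy to 2-methylphenoxy gives an at least 2.6-fold lower number from compound 1 to compound 4 (0.41 log units; beyond the scatter), so a second replacement group, after the 3-chlorophenyl group of compound 2, now clears the scatter from compound 1. Compound 1 stands at a limit and not at a number, so this step is a floor and not a measured size: the limit of > 25000 nM in this assay, at which 1 of the 4 values shown sits. Methyl in place of bromo on an aromatic carbon gives a 2.3-fold lower number from compound 3 to compound 4 (0.36 log units; beyond the scatter), which shows that this single exchange on the ring is enough to move the read-out, whereas a 1.1-fold higher number from compound 2 to compound 4 (0.06 log units; within the scatter) leaves no difference to read between the 2-methylphenyl and 3-chlorophenyl groups.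

The compounds shown leave open how an unsubstituted phenyl ring, or a methoxy, trifluoromethyl or nitrile group on that ring, would behave on the oxygen. They also leave open the true size of the step from compound 1, why these groups differ, and whether a shorter or longer chain in place of the six-carbon linker would change the picture.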